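A few compounds are considered here, and "the series" means these few. Any claim that something is new, unique, unknown or untested is made for them only; others in the source may bear on it.

Measured so far in a functional assay on the whole organism for inhibition, with Scenedesmus acutus as the target; on this read-out higher numbers stand for weaker inhibition and lower numbers for stronger inhibition:

- compound 1 `Cc1cc(Cl)ccc1/N=c1\sc(=S)n2n1CCCC2`: 457 nM
- compound 2 `CC(C)Oc1cc(-n2c(=S)n3n(c2=S)CCCC3)c(F)cc1Cl`: 7.59 nM
- compound 3 `Cc1cc(Cl)ccc1-n1c(=S)n2n(c1=S)CCCC2`: 105 nM

Compound 1, at 457 nM, has the highest number of the three and is therefore the weakest inhibitor so far. Both other compounds lie lower by more than the usual scatter of repeated measurements, compound 3 being the nearer and compound 2 the further.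

The next compound is compound 4 `Fc1cc(Cl)ccc1/N=c1\sc(=S)n2n1CCCC2`, which keeps the core of compound 1 and changes one small group: fluoro in place of methyl on an aromatic carbon. This carbon is ortho to a large group and meta to a chloro group.

For the measured compounds named here, no measured pair shows this exact swap, so the evidence is indirect. Compound 2 carries a fluoro on its aromatic ring and gives 7.59 nM, while compound 3 carries a methyl and gives 105 nM. These two differ in other places as well, so their gap is only a faint hint, and neither shares the core of compound 1.

A modest move towards stronger inhibition in this assay is therefore expected, at about the edge of the scatter, with the estimated change being a 2.1-fold lower number from compound 1 to compound 4 (0.32 log units; beyond the scatter). For compound 4 the estimated value is 220 nM, with an expected range from 70 nM to 700 nM.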

Compound 4, half-maximal inhibitory concentration: 120 nM
Beside the measured number, compound 4's estimate is 1.8-fold (0.26 log units) above it; measured number inside the range.
By their numbers in this assay, from the lowest: compound 2; then compounds 3 and 4 (each within the scatter of the next); then compound 1.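

On the core of compound 1, the aromatic carbon that is ortho to a large group and meta to a chloro group now has a direct reading: in this assay, fluoro in place of methyl gives a 3.8-fold lower number from compound 1 to compound 4 (0.58 log units; beyond the scatter) and so moves towards stronger inhibition. This is the first pair among the compounds shown that differs in one place only, and it shows that exchanging this single heavy atom is enough to shift the number beyond the usual scatter, although the step is still a modest one. Nothing measured here gives a reason for the shift.

The compounds shown leave open whether the same exchange would produce a step of similar size on the core of compound 3, since only one pair carries this change and it sits on a single core. They also leave open how the number would respond to a plain hydrogen, a methoxy group, a nitrile or an amine on this same aromatic carbon, so a single exchange cannot yet show a trend for this position.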